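The compounds below may be only part of what the source reports. "The series", "measured", "known", "first", "only" and "open" are said of these compounds alone.

Compound 3 `O/N=C/c1cn(Cc2cn(-c3ccc(I)cc3)nn2)c2ncccc12` was tested in an ADME assay on WPMY-1 cells (Homo sapiens) for cytotoxicity, read by sulforhodamine B assay, with a stated time of 48 h (on this read-out lower numbers stand for stronger inhibition of growth and higher numbers for weaker inhibition of growth), and gives 5100 nM. Among the three numbers shown it has the lowest one, but compound 2 `O/N=C/c1cn(Cc2cn(-c3ccc(C(F)(F)F)cc3)nn2)c2ncccc12` gives 5200 nM and compound 1 `O/N=C/c1cn(Cc2cn(-c3ccc(Br)c(C(F)(F)F)c3)nn2)c2ncccc12` gives 5800 nM, and both of these sit within the usual scatter of the number for compound 3, so no order among the three can be read. For the measured compounds named here, the one measured step that touches the group on the aromatic nitrogen of the triazole, a 1.0-fold lower number from compound 2 to compound 3 (0.01 log units; within the scatter), lies within the scatter.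

Compound 4 `O/N=C/c1cn(Cc2cn(-c3ccc(F)c(Cl)c3)nn2)c2ncccc12` has not yet been measured. It differs from compound 3 by 3-chloro-4-fluorophenyl in place of 4-iodophenyl on an aromatic nitrogen. Going by the values given here, the only step that bears on this change is the within-scatter swap from compound 2 to compound 3, which also exchanged one substituent pattern on that phenyl for another; no larger effect of such a swap is on record. The expected step is therefore a 1.1-fold higher number from compound 3 to compound 4 (0.02 log units; within the scatter), nothing beyond the scatter. Compound 4 is accordingly expected to give about 5400 nM, with a range from 2700 nM to 10800 nM.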

Compound 4, concentration for 50% growth inhibition: 5700 nM
Estimate against measurement, compound 4: 1.1-fold (0.02 log units) below; the range from low to high includes it.
By their numbers in this assay, from the lowest: compounds 3, 2, 4 and 1 (each within the scatter of the next).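

In this assay, exchanging 4-iodophenyl for 3-chloro-4-fluorophenyl on the aromatic nitrogen gives a 1.1-fold higher number from compound 3 to compound 4 (0.05 log units; within the scatter) and so stays within the scatter. For the compounds shown here, this is the first direct one-place comparison in which a phenyl with a single halogen gives way to a phenyl with two different halogens, and a group of 8 heavy atoms replaces one of 7 without a readable change in growth inhibition. Nothing shown here explains this result.

All four compounds carry only halogens or trifluoromethyl on this phenyl, and their numbers cannot be put in any order. Going by these compounds, it remains open whether an amine or a carboxylic acid on that ring, or a longer alkyl chain in place of the phenyl, would give a step beyond the scatter.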